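The source may report more compounds than this note shows. Statements on the series, on what has been measured and on what is new or still open speak of the compounds shown alone.

Measured compounds:
compound 1, `Fc1cccc(F)c1C#Cc1ccnc2ccccc12`, 15.4%
compound 2, `Fc1cccc(F)c1C#Cc1ccnc2cc(Cl)ccc12`, 36%
compound 3, `Fc1cccc(F)c1C#Cc1ccc2ncccc2c1`, 11%

All three were tested in a functional assay on LS174T cells (Homo sapiens) for inhibition, with a stated time of 4 days, tested at 1 uM; on this read-out lower numbers stand for a weaker effect and higher numbers for a stronger effect at the one concentration tested. Compound 1 and compound 2 share one core; compound 3 has a core of the same atoms joined differently, and the difference between the two cores is not broken down here. In this assay compound 2 reaches 36%, while compound 1 gives 15.4% and compound 3 gives 11%; the numbers for compound 1 and compound 3 lie within the usual scatter of each other, so nothing separates them.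

Going by the values given here, the one counted step among the measured compounds is chloro in place of hydrogen on an aromatic carbon, which brought a number 20.6 percentage points higher from compound 1 to compound 2 (beyond the scatter). Compound 4, `Fc1cccc(F)c1C#Cc1ccc2nc(Cl)ccc2c1`, is not yet measured. It arises from compound 3 by chloro in place of hydrogen on an aromatic carbon. Among the compounds with values here, this is the same kind of change as the one from compound 1 to compound 2, but not the same: in compound 2 the chloro sits on a six-membered aromatic ring of carbon only, whereas in compound 4 it sits on a six-membered aromatic ring with one nitrogen, next to the ring nitrogen. Because the change from compound 1 to compound 2 gave a number 20.6 percentage points higher from compound 1 to compound 2 (beyond the scatter), an increase is expected for compound 4 as well, though a smaller one, since the place of the chloro is not the same. The step from compound 3 to compound 4 is estimated at a number 11 percentage points higher from compound 3 to compound 4 (beyond the scatter). For compound 4 in this assay the expected value is 22%, likely between 6% and 40%.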

Compound 4, a percentage reported as inhibition, at one concentration (the size of the read-out at that concentration, not a potency): 21.2%
Estimate against measurement, compound 4: 0.8 percentage points above; the measured number falls inside the stated range.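

In this assay, putting chloro in place of hydrogen on the core of compound 3 gave a number 10.2 percentage points higher from compound 3 to compound 4 (beyond the scatter), so this change goes with a higher number on both cores shown. Set side by side, the two steps point the same way and cannot be told apart in size: the same change on two cores in this assay, a number 20.6 percentage points higher (beyond the scatter) from compound 1 to compound 2 and a number 10.2 percentage points higher (beyond the scatter) from compound 3 to compound 4, 10.4 percentage points apart, within the scatter of two such steps. Going by these compounds alone, this supports carrying the change from one of these cores to the other, but it rests on only two pairs of compounds, with the chloro not in the same place on the two cores, so it cannot separate the effect of the core from that of the chloro's place, and it says nothing about why the number rises or whether the same would happen on any further core.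

The compounds shown leave open whether another group at the same place on the aromatic carbon, such as a methyl, a methoxy, an amine or a carboxylic acid, would raise the number as chloro does, or whether only chloro does so. On these data alone, each number also comes from a single concentration, so it shows only a stronger or weaker effect at that concentration, and how the compounds would compare at other concentrations remains open too.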